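The source may hold more compounds than are shown below. What is called first, only, known or untested is meant among the compounds shown, and "the series" means these compounds.

Of the compounds shown here, three built on one shared core have been tested in an ADME assay on Vero cells (Chlorocebus sabaeus) for cytotoxicity, read by polymerase chain reaction, with a stated time of 18 h; a higher number here means that more compound is tolerated, a lower number that less compound is tolerated. Compound 1 `O=c1cc(CSc2nc3ccccc3c(=O)[nH]2)c2ccc(OS(=O)(=O)c3ccc(F)cc3)cc2o1` gives 30000 nM. Compound 2 `O=c1cc(CSc2nc3ccccc3c(=O)[nH]2)c2ccc(OS(=O)(=O)c3ccc([N+](=O)[O-])cc3)cc2o1` gives 117000 nM, and compound 3 `O=c1cc(CSc2nc3ccccc3c(=O)[nH]2)c2ccc(OS(=O)(=O)c3ccccc3[N+](=O)[O-])cc2o1` gives 144000 nM. Compound 3 therefore holds the highest of the three numbers, but compound 2 sits within the scatter of it, so the two cannot be told apart; only compound 1 is clearly separated. The measured steps are a 3.9-fold higher number from compound 1 to compound 2 (0.59 log units; beyond the scatter), a 4.8-fold higher number from compound 1 to compound 3 (0.68 log units; beyond the scatter) and a 1.2-fold higher number from compound 2 to compound 3 (0.09 log units; within the scatter).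

The next compound, compound 4 `Cc1ccc(COc2ccc3c(CSc4nc5ccccc5c(=O)[nH]4)cc(=O)oc3c2)cc1`, differs from compound 3 in one place: 4-methylbenzyl in place of (2-nitrophenyl)sulfonyl on an oxygen on an aromatic ring. None of the three measured steps bears directly on this change, since each of them swaps fluoro for nitro or moves the nitro on the ring attached to the sulfonyl sulfur, while the sulfonyl itself stays in every measured compound. The change to compound 4 removes that whole group, so the measured steps give no direction for it, and any expectation must be wide. A step of about a 2.4-fold lower number from compound 3 to compound 4 (0.38 log units; beyond the scatter) is expected, leaning toward a lower number because the group that leaves is part of what carried compound 3 to 144000 nM. Compound 4 is estimated at 60000 nM, with a range from 15000 nM to 200000 nM.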

Compound 4, half-maximal cytotoxic concentration: 102000 nM
Estimate against measurement, compound 4: 1.7-fold (0.23 log units) below, within the range that was stated.
By their numbers in this assay, from the lowest: compound 1; then compounds 4, 2 and 3 (each within the scatter of the next).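

In this assay, the whole (2-nitrophenyl)sulfonyl group on the oxygen can give way to 4-methylbenzyl, which has no nitrogen, no sulfur and no hydrogen-bond acceptors, with no separable shift in the number (a 1.4-fold lower number from compound 3 to compound 4 (0.15 log units; within the scatter)), and the same holds against the (4-nitrophenyl)sulfonyl group (a 1.1-fold lower number from compound 2 to compound 4 (0.06 log units; within the scatter)). A sulfonyl on this oxygen is therefore not needed to reach numbers of this size among these compounds, whereas replacing (4-fluorophenyl)sulfonyl with the same 4-methylbenzyl gives a clear difference (a 3.4-fold higher number from compound 1 to compound 4 (0.53 log units; beyond the scatter)), leaving compound 1 as the only compound set apart from the rest. No measurement here explains these results.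

Every group on this oxygen so far carries a six-membered aromatic ring of carbon only, so a plain methyl, a longer alkyl chain or a chain ending in an amine would show whether that ring matters at all. Also open, from the compounds shown here alone, is whether the lower number of compound 1 follows the fluoro group itself, which a 4-fluorobenzyl group in place of 4-methylbenzyl would test.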